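A few compounds are considered here, and "the series" means these few. Any claim that something is new, unique, unknown or untested is made for them only; others in the source may bear on it.

Measured so far in an in vitro functional assay on cells for agonist activity at Bombesin receptor subtype-3 (Mus musculus), read by luminescence and calcium flux; a lower number here means that less compound is needed, a higher number that more compound is needed for the effect:
compound 1 `COc1ccc(Cc2cnc(CCc3ccc(-c4ccccc4C(=O)O)cc3)[nH]2)cc1`: 513 nM
compound 2 `O=C(O)c1ccccc1-c1ccc(CCc2ncc(Cc3ccc(F)cc3)[nH]2)cc1`: 50 nM
compound 3 `O=C(O)c1ccccc1-c1ccc(CCc2ncc(CC3CCCCCC3)[nH]2)cc1`: 5.7 nM

Compound 3 stands lowest of the three numbers. Its nearest neighbour is reached by the step of an 8.8-fold lower number from compound 2 to compound 3 (0.94 log units; beyond the scatter), its furthest by the step of a 90-fold lower number from compound 1 to compound 3 (1.95 log units; beyond the scatter); both steps lie beyond the scatter, so compound 3 is the most potent of the set in this assay.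

Compound 4 `O=C(O)c1ccccc1-c1ccc(CCc2ncc(Cc3cccc(Cl)c3)[nH]2)cc1` has not been measured. It differs from compound 3 in one place: 3-chlorophenyl in place of cycloheptyl on a saturated chain carbon bound to an aromatic carbon. Going by the values given here, two measured steps bear on this change, since both replace an aromatic ring at this saturated chain carbon with the cycloheptyl ring: a 90-fold lower number from compound 1 to compound 3 (1.95 log units; beyond the scatter) and an 8.8-fold lower number from compound 2 to compound 3 (0.94 log units; beyond the scatter), both large and both toward lower numbers. The step of a 10-fold lower number from compound 1 to compound 2 (1.01 log units; beyond the scatter) further shows that the choice of substituent on such an aromatic ring moves the number by a large amount. Among the compounds with values here, compound 4 runs the aryl-for-cycloheptyl exchange in reverse, so a higher number is expected; the chloro-bearing ring of compound 4 has no exact precedent, but a step of the size a 5.3-fold higher number from compound 3 to compound 4 (0.72 log units; beyond the scatter) is estimated, smaller than the loss seen with the fluoro ring of compound 2. Compound 4 is therefore expected to give about 30 nM in this assay, within roughly 8 nM to 120 nM.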

Compound 4, half-maximal effective concentration: 31 nM
For compound 4 the middle estimate is 1.0-fold (0.01 log units) below the measured one, and the stated range covers the measured number.
By their numbers in this assay, from the lowest: compound 3; then compounds 4 and 2 (each within the scatter of the next); then compound 1.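

In this assay, a 5.4-fold higher number from compound 3 to compound 4 (0.74 log units; beyond the scatter) shows that cycloheptyl on this saturated chain carbon also gives the lowest number against 3-chlorophenyl, so the same holds against all three aromatic rings shown, with no compound going against it. The step of a 1.6-fold lower number from compound 2 to compound 4 (0.21 log units; within the scatter) leaves 3-chlorophenyl and 4-fluorophenyl unresolved here, even though the two rings differ in both halogen and substitution place, while a 17-fold lower number from compound 1 to compound 4 (1.22 log units; beyond the scatter) joins the earlier step from compound 1 in setting 4-methoxyphenyl apart from both halogen-bearing rings. No measurement is available that explains these differences.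

Cyclohexyl or cyclopentyl at this carbon would test whether the low number of compound 3 depends on the seven-membered ring or extends to smaller non-aromatic rings of carbon only. A 4-chlorophenyl group would separate the identity of the halogen from its place on the ring, which the comparison of compound 2 and compound 4 cannot do, and a 3-fluorophenyl group would provide the matching check from the other direction.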